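This account rests on a few compounds, and the source may have more. Where it says the series, first, only, none or still open, it means among the compounds named here.

Of the compounds shown here, three from one series have been measured in an assay on lysate for inhibition of 6-phosphofructo-2-kinase/fructose-2,6-bisphosphatase 3 (Homo sapiens), with stated times of 0.5 min and 45 min; a higher number here means a weaker inhibitor, a lower number a stronger inhibitor. Compound 1 `Cn1ccc2ccc(-c3cc(Nc4ccccc4S(N)(=O)=O)cc4nccnc34)cc21` gives 37600 nM in this assay, and compound 2 `CN1CCC(NS(=O)(=O)c2ccccc2Nc2cc(-c3ccc4ccn(C)c4c3)c3nccnc3c2)C1`, which carries a substituted sulfonamide, gives 3160 nM. Among the compounds with values here, the one step counted between measured compounds, a 12-fold lower number from compound 1 to compound 2 (1.08 log units; beyond the scatter), is the only measured change on a side-chain nitrogen in this set. Compound 3 `Cn1cc(NC(=O)c2ccncc2Nc2cc(-c3ccc4ccn(C)c4c3)c3nccnc3c2)cn1` gives 26500 nM in this assay; it stands second highest of the three numbers, close to compound 1 and well above compound 2.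

Compound 4 `CC(=O)N1CCCC(NC(=O)c2ccncc2Nc2cc(-c3ccc4ccn(C)c4c3)c3nccnc3c2)C1` differs from compound 3 in one place: 1-acetylpiperidin-3-yl in place of 1-methyl-1H-pyrazol-4-yl on an amide-type nitrogen. Within the data shown here, no measured pair shows this exact change. The step from compound 1 to compound 2 bears on it only loosely, since there a saturated nitrogen-containing ring replaced a hydrogen, whereas here a saturated ring replaces an aromatic one on a different kind of nitrogen. That step was large and in the favourable direction, so a smaller step in the same direction is expected here, with real uncertainty.

The estimated step from compound 3 to compound 4 in this assay is a 2.7-fold lower number from compound 3 to compound 4 (0.42 log units; beyond the scatter). Compound 4 is therefore expected to give about 10000 nM in this assay, within a range of 3000 nM to 30000 nM.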

Compound 4, half-maximal inhibitory concentration: 13500 nM
For compound 4 the middle estimate is 1.4-fold (0.13 log units) below the measured one; low and high end bracket the measured number.
By their numbers in this assay, from the lowest: compound 2; then compounds 4, 3 and 1 (each within the scatter of the next, the first and the last beyond it).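

In this assay, placing 1-acetylpiperidin-3-yl in place of 1-methyl-1H-pyrazol-4-yl on the amide-type nitrogen gives a 2.0-fold lower number from compound 3 to compound 4 (0.29 log units; within the scatter), so compound 3 and compound 4 cannot be told apart in this measurement. Within the data shown here, this is the first reading at this position, and it shows that a five-membered aromatic ring and a larger six-membered non-aromatic ring carrying an acetyl group can stand on this nitrogen with no separable difference in the number. Nothing available explains why these two groups read alike.

The compounds shown leave open how a piperidin-3-yl group with a free ring amine, or an open chain ending in a dimethylamino group, would read on this amide-type nitrogen. Among these compounds, they also leave open whether the change on the sulfonamide nitrogen, a 12-fold lower number from compound 1 to compound 2 (1.08 log units; beyond the scatter), would carry over to the amide-type nitrogen, as no pair here places the same group on both.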